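The source may hold more compounds than are shown below. What is called first, only, known or untested is meant among the compounds shown, and "the series" means these compounds.

In a functional assay on PANC-1 cells (Homo sapiens) for inhibition, read by MTT assay, with a stated time of 24 h, tested at 10 uM (on this read-out higher numbers stand for more inhibition at the one concentration tested (going by the name of the read-out) and lower numbers for less inhibition), compound 1 `CC(C)=CCC/C(C)=C/CC1Cc2c(OCCCNC(=O)c3cccs3)cc(=O)n(CCCO)c2CC1(C)C` gives 11.5%, while compound 2 `COc1ccccc1NC(=O)Oc1cc(=O)n(CCCO)c2c1CC(C/C=C(\C)CCC=C(C)C)C(C)(C)C2` gives 0%, the lower of the two numbers; the step of a number 11.5 percentage points lower from compound 1 to compound 2 (beyond the scatter) lies beyond the scatter. Compound 3 `CC(C)=CCC/C(C)=C/CC1Cc2c(OC(=O)Nc3cccc(F)c3)cc(=O)n(CCCO)c2CC1(C)C` differs from compound 2 by 3-fluorophenyl in place of 2-methoxyphenyl on an amide-type nitrogen. Among the measured compounds shown here, no measured step exchanges one aryl group for another on the amide-type nitrogen; the single measured step replaces the whole side chain on the ring oxygen and so gives no direct guide. One therefore expects a move of a number 3 percentage points higher from compound 2 to compound 3 (within the scatter) for compound 3, not beyond the scatter. Compound 3 is estimated at 3%, within a range from 0% to 15%.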

Compound 3, a percentage reported as inhibition, at one concentration (the size of the read-out at that concentration, not a potency): 0%
The estimate for compound 3 lay 3 percentage points above the measured number; the measured number falls inside the stated range.
By their numbers in this assay, from the lowest: compounds 2 and 3 (each within the scatter of the next); then compound 1.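

In this assay, among the compounds shown here, the first aryl-for-aryl exchange on the amide-type nitrogen, 3-fluorophenyl in place of 2-methoxyphenyl, separates nothing, with no change at the digits printed from compound 2 to compound 3 (within the scatter). Replacing the side chain on the ring oxygen with a second carbamoyl gives the same drop, with a number 11.5 percentage points lower from compound 1 to compound 3 (beyond the scatter), so this drop does not depend on which of these two aryl groups is present. Nothing at hand bears on the reason for this result.

As far as these compounds go, it remains open whether an amine or a carboxylic acid on the aryl ring would raise the number at this position. From the compounds shown here alone, it is also open whether a longer chain between the carbamoyl nitrogen and the ring would do so.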